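Chalcone series: removing the chloro on the trimethoxy member

A few compounds are considered here, and "the series" means these few. Any claim that something is new, unique, unknown or untested is made for them only; others in the source may bear on it.

Measured so far:
- compound 1, `COc1cc(/C=C/C(=O)c2cccc(-n3cc(-c4ccc(Cl)cc4)[nH]c3=O)c2)cc(OC)c1OC`, gives 5450 nM in a functional assay on KM12 cells (Homo sapiens) for inhibition; a lower number here means a stronger inhibitor of growth, a higher number a weaker inhibitor of growth
- compound 2, `COc1cc(/C=C/C(=O)c2cccc(-n3cc(-c4ccccc4)[nH]c3=O)c2)ccc1O`, gives 1610 nM in this assay
- compound 3, `O=C(/C=C/c1cccc(O)c1)c1cccc(-n2cc(-c3ccc(Cl)cc3)[nH]c2=O)c1`, gives 1340 nM in this assay

Compound 1 stands at the highest number of the three, so it is the weakest inhibitor of growth among them; compound 2 lies nearest to it and compound 3 furthest, and both gaps are beyond the scatter. Among the measured compounds shown here, no pair of measured compounds differs in a single place, so no single step can be read off: compound 2 and compound 3 differ from compound 1 both on the phenyl attached to the core and on the cinnamoyl ring.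

Compound 4, `COc1cc(/C=C/C(=O)c2cccc(-n3cc(-c4ccccc4)[nH]c3=O)c2)cc(OC)c1OC`, is compound 1 with hydrogen in place of chloro on an aromatic carbon; read one bond further out, 4-chlorophenyl becomes phenyl. For the measured compounds named here, the only measured compound carrying phenyl here, compound 2, sits at a lower number than compound 1, but its cinnamoyl ring is also changed, so the pull of the chloro alone cannot be separated. The step from compound 1 to compound 4 is expected to be modest, toward a lower number, as a 1.8-fold lower number from compound 1 to compound 4 (0.26 log units; within the scatter). For compound 4 the estimate in this assay is 3000 nM, in the range 1000 nM to 9000 nM.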

Compound 4, concentration for 50% growth inhibition: 1370 nM
For compound 4 the middle estimate is 2.2-fold (0.34 log units) above the measured one, within the range that was stated.
By their numbers in this assay, from the lowest: compounds 3, 4 and 2 (each within the scatter of the next); then compound 1.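

With the trimethoxy-substituted cinnamoyl ring held constant, the effect of the chloro can now be read on its own: in this assay, hydrogen in place of chloro gives a 4.0-fold lower number from compound 1 to compound 4 (0.60 log units; beyond the scatter). On this member, therefore, the 4-chlorophenyl group gives weaker growth inhibition than phenyl, and the size of the step is beyond the usual scatter. Nothing at hand explains this difference.

This single pair does not show whether the step carries over to other cinnamoyl rings, such as the hydroxy-bearing rings of compound 2 and compound 3. Also open, on these data alone, is how a fluoro, methyl, methoxy or dimethylamino group at the same position on the phenyl ring would compare with chloro and hydrogen.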